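This account rests on a few compounds, and the source may have more. Where it says the series, first, only, none or still open, it means among the compounds named here.

Compounds measured in an ADME assay for permeability, using PAMPA, with a stated time of 30 min, at pH 7.4; on this read-out higher numbers stand for higher permeability and lower numbers for lower permeability:
- compound 1 `COc1ccc(F)cc1CNCCCNc1ccnc2cc(Cc3cc(C)cc(C)c3)ccc12`, which gives 23 10^-6 cm/s
- compound 2 `COc1ccc(F)cc1CNCCCNc1ccnc2cc(CC3CCCCC3)ccc12`, which gives 23 10^-6 cm/s
- compound 3 `COc1ccccc1Oc1ccc2c(NCCCNCc3cccc(OC)c3O)ccnc2c1`, which gives 317 10^-6 cm/s

Compound 3 stands highest of the three in this assay; its gaps to compound 1 and to compound 2 are both beyond the scatter. Compound 4 `COc1ccc(F)cc1CNCCCNc1ccnc2cc(Oc3ccccc3OC)ccc12` is not yet measured. It differs from compound 3 in one place: 5-fluoro-2-methoxyphenyl in place of 2-hydroxy-3-methoxyphenyl on a saturated chain carbon bound to an amine nitrogen. Within the data shown here, the only measured step, no change at the digits printed from compound 1 to compound 2 (within the scatter), concerns a group on the saturated chain carbon bound to an aromatic carbon at the other end of the shared core, and so does not speak to the change on the benzyl carbon made here. Compound 1 and compound 2 carry the same 5-fluoro-2-methoxybenzyl group as compound 4, but they also differ from compound 3 at the other end, so their numbers cannot be read as a clean guide. Among the measured compounds shown here, with no direct precedent, the step is estimated as a 1.1-fold lower number from compound 3 to compound 4 (0.02 log units; within the scatter). Compound 4 is therefore expected to give about 300 10^-6 cm/s in this assay, most likely between 120 10^-6 cm/s and 700 10^-6 cm/s.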

Compound 4, apparent permeability: 317 10^-6 cm/s
Compound 4: middle estimate off by 1.1-fold (0.02 log units), on the low side, and the stated range covers the measured number.
By their numbers in this assay, from the lowest: compounds 1 and 2 (each within the scatter of the next); then compounds 3 and 4 (each within the scatter of the next).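

In this assay, 5-fluoro-2-methoxyphenyl in place of 2-hydroxy-3-methoxyphenyl on a saturated chain carbon bound to an amine nitrogen gives no change at the digits printed from compound 3 to compound 4 (within the scatter), even though the entering group counts 0 hydrogen-bond donors against 1 in the group it replaces. With the 5-fluoro-2-methoxybenzyl group held constant, 2-methoxyphenoxy on an aromatic carbon gives a 14-fold higher number from compound 2 to compound 4 (1.14 log units; beyond the scatter) in place of cyclohexylmethyl and a 14-fold higher number from compound 1 to compound 4 (1.14 log units; beyond the scatter) in place of 3,5-dimethylbenzyl, so the large steps in this set lie at that aromatic carbon and not at the benzyl carbon. No measurement offered here explains either result.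

Going by these compounds, this rests on a single pair at the benzyl carbon, so it remains open whether the same holds for a benzyl group carrying a carboxylic acid or a pyridine ring in place of the benzene ring. On these data alone, it also remains open whether a simple phenoxy group would match 2-methoxyphenoxy on the aromatic carbon.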